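The compounds below may be only part of what the source reports. "The series", "measured", "known", "first", "only" and "open" are said of these compounds alone.

In an ADME assay on MT4 cells (Homo sapiens) for cytotoxicity, read by MTT assay (a higher number here means that more compound is tolerated, a lower number that less compound is tolerated), compound 1 (`CCCCCCC1C(=O)N(O)C(=O)c2ccccc21`) gives 4400 nM and shares the low end of the measured set with compound 3 (`O=C1c2ccccc2C(Cc2ccc(C(F)(F)F)cc2)C(=O)N1O`), which gives 6000 nM within the scatter of compound 1. Compound 2 (`O=c1c2ccccc2c(Cc2ccccc2)c(O)n1O`) gives 88000 nM and lies beyond the scatter, higher than compound 1. Compound 4 (`O=C1c2ccccc2C(CCCc2ccccc2)C(=O)N1O`) differs from compound 1 by phenyl in place of propyl on a saturated chain carbon, three bonds along the chain from a saturated ring carbon with phenyl in place of propyl on a saturated chain carbon, three bonds along the chain from a saturated ring carbon. Among the compounds with values here, no measured pair isolates this change. Compound 3 also carries a ring on its side group and stays at 6000 nM in this assay, while compound 2, with its own ring, goes against that at 88000 nM and leaves room upward. The expected change is a small upward one, a 2.3-fold higher number from compound 1 to compound 4 (0.36 log units; beyond the scatter) in this assay, and it may not clear the scatter. For compound 4 the estimate is 10000 nM with an expected range of 3000 nM to 40000 nM in these notes.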

Compound 4, half-maximal cytotoxic concentration: 5200 nM
Compound 4: middle estimate off by 1.9-fold (0.28 log units), on the high side, and the stated range covers the measured number.
By their numbers in this assay, from the lowest: compounds 1, 4 and 3 (each within the scatter of the next); then compound 2.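

Within the data shown here, the step of a 1.2-fold higher number from compound 1 to compound 4 (0.07 log units; within the scatter) in this assay is the first readable change at this position: phenyl in place of propyl on a saturated chain carbon, three bonds along the chain from a saturated ring carbon. This swap adds an aromatic ring, yet the step stays within the scatter, so on this pair the read-out does not separate the two groups. No measured evidence bears on this result.

Open, on these data alone, is whether an amine or a carboxylic acid in place of phenyl at this position would give a step beyond the scatter. A longer chain carrying the phenyl is equally untested by the compounds shown.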